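From benzyl to phenyl on the shared core

The source may hold more compounds than are shown below. What is called first, only, known or untested is meant among the compounds shown, and "the series" means these compounds.

Measured in a functional assay on L1210 cells (Mus musculus) for inhibition, read by cell counting, with a stated time of 2 days; a lower number here means a stronger inhibitor, a higher number a weaker inhibitor:
compound 1, `C=C(Br)C(=O)Nc1cccc(-c2cn3nc(-c4ccc(CC)cc4)sc3n2)c1`, 2200 nM
compound 2, `C=C(Br)C(=O)Nc1cccc(-c2cn3nc(Cc4cccc(OC)c4)sc3n2)c1`, 2000 nM
compound 3, `C=C(Br)C(=O)Nc1cccc(-c2cn3nc(Cc4ccccc4)sc3n2)c1`, 3000 nM

Compound 3 stands highest of the three numbers; its nearest neighbour is compound 1 and its furthest is compound 2, and both gaps lie within the scatter, so no order among them can be claimed. Compound 4, `C=C(Br)C(=O)Nc1cccc(-c2cn3nc(-c4ccccc4)sc3n2)c1`, has not been measured; it differs from compound 3 by phenyl in place of benzyl on an aromatic carbon. Among the compounds with values here, one measured step bears on this: a 1.4-fold higher number from compound 1 to compound 3 (0.13 log units; within the scatter), which exchanged 4-ethylphenyl for benzyl on the same carbon and stayed within the scatter. Likewise a 1.5-fold higher number from compound 2 to compound 3 (0.18 log units; within the scatter) stayed within the scatter. Compound 4 is therefore expected to show no step beyond the scatter, a 1.2-fold lower number from compound 3 to compound 4 (0.08 log units; within the scatter). The estimate for compound 4 is 2500 nM, with a range from 1200 nM to 5200 nM.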

Compound 4, half-maximal inhibitory concentration: 600 nM
Compound 4: the middle estimate sits 4.2-fold (0.62 log units) above what was measured, outside the stated range (below it).
By their numbers in this assay, from the lowest: compound 4; then compounds 2, 1 and 3 (each within the scatter of the next).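

In this assay the aromatic carbon of the five-membered ring proved responsive: phenyl in place of benzyl gave a 5.0-fold lower number from compound 3 to compound 4 (0.70 log units; beyond the scatter) and was the first step there beyond the scatter. Phenyl in place of 3-methoxybenzyl gave a 3.3-fold lower number from compound 2 to compound 4 (0.52 log units; beyond the scatter) as well, and hydrogen in place of ethyl gave a 3.7-fold lower number from compound 1 to compound 4 (0.56 log units; beyond the scatter) on the otherwise identical phenyl compound. Nothing measured here accounts for these steps.

Still open, on these data alone, is whether methyl, an amine or a carboxylic acid on that phenyl ring would keep the number of compound 4.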